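Swapping the aryl group on a sulfonyl sulfur

The source may hold more compounds than are shown below. What is called first, only, known or untested is meant among the compounds shown, and "the series" means these compounds.

Compound 1 `CC1CCN(C2CCN(S(=O)(=O)c3cnc(Cl)s3)CC2)CC1`: > 10000 nM (a limit)
Compound 2 `Cc1nc(Cl)sc1S(=O)(=O)N1CCC(N2CCC(C)CC2)CC1`: > 10000 nM (a limit)
Compound 3 `CC1CCN(C2CCN(S(=O)(=O)c3ccc(F)cc3F)CC2)CC1`: > 5000 nM (a limit)

All three entries come from an ADME assay on HCT-116 cells (Homo sapiens) for cytotoxicity, read by CellTiter-Glo, with a stated time of 72 h (on this read-out higher numbers stand for weaker inhibition and lower numbers for stronger inhibition), and none of them is an exact number. Compound 3 stands at the limit of > 5000 nM in this assay, at which 1 of the 3 values shown sits. Compound 1 and compound 2 stand at the limit of > 10000 nM in this assay, at which 2 of the 3 values shown sit.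

Compound 4 `CC1CCN(C2CCN(S(=O)(=O)c3ccc(Cl)c(Cl)c3)CC2)CC1` has not been measured yet. Its difference from compound 3 is 3,4-dichlorophenyl in place of 2,4-difluorophenyl on a sulfonyl sulfur. The rest of the molecule stays the same.

Two measured steps exchange the group on that same sulfonyl sulfur: a step that the two limits leave unreadable from compound 1 to compound 3 and a step that the two limits leave unreadable from compound 2 to compound 3. A third step, a step that the two limits leave unreadable from compound 1 to compound 2, is a methyl in place of hydrogen on an aromatic carbon, so it bears less on this change. None of these steps has a readable size, which leaves no measured direction to follow.

No shift beyond the usual scatter is therefore expected in this assay, and compound 4 will most likely be reported as a limit too. The estimated step is a step that the limit leaves unreadable from compound 3 to compound 4. For compound 4 the expected value is 8000 nM, with an estimated range from 3000 nM to 20000 nM.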

Compound 4, half-maximal inhibitory concentration: > 5000 nM
Compound 4: a limit, no number; the forecaster's own chance of this, stated with the estimate: 75%; the middle value is on the limit's open side.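

In this assay compound 4 gives > 5000 nM, which is a limit and not an exact number. All four entries are limits, so the steps from compound 1, compound 2 and compound 3 to compound 4 cannot be read. The compounds shown leave open whether exchanging the group on the sulfonyl sulfur changes the inhibition at all, and by how much.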